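The compounds below may be only part of what the source reports. "The series", "measured", "known", "first", "only" and "open" are said of these compounds alone.

Measured so far in an assay on Sf21 cells for inhibition of mitogen-activated protein kinase kinase kinase 13 (Homo sapiens), read by HTRF, with a stated time of 1.5 h; on this read-out lower numbers stand for stronger inhibition and higher numbers for weaker inhibition:

Compound 1 `Nc1ncc(-c2cc([C@@H]3CCCO3)nc(N3C[C@@H]4C[C@H]3CO4)n2)nc1OC(F)F`: 23 nM
Compound 2 `Nc1ncc(-c2cc(C3CC3)cc(N3C[C@@H]4C[C@H]3CO4)n2)nc1OC(F)F`: 75 nM

Compound 1 gives the lowest of the two numbers in this assay. Its nearest neighbour, compound 2, lies beyond the usual scatter above it; the two differ in more than one place, so nothing in this pair isolates a single change.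

The next compound, compound 3 `Nc1ncc(-c2cc(N3CC4CC3C4)nc(N3C[C@@H]4C[C@H]3CO4)n2)nc1OC(F)F`, differs from compound 1 in one place: a group of 6 heavy atoms (5 carbon, 1 nitrogen; one four-membered non-aromatic ring of carbon only, one five-membered non-aromatic ring with 1 hetero atom) in place of a group of 5 heavy atoms (4 carbon, 1 oxygen; one five-membered non-aromatic ring with 1 hetero atom), on an aromatic carbon. The group that leaves is the oxolan-2-yl; the group that enters carries one four-membered non-aromatic ring of carbon only fused with one five-membered non-aromatic ring with one hetero atom, and keeps the count of one hydrogen-bond acceptor and no donors. The place is on an aromatic carbon of the six-membered aromatic ring with two nitrogen, next to the ring nitrogen.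

Among the compounds with values here, no step between measured compounds covers this change, so the expectation rests on compound 1 alone. A modest step is expected, from compound 1 to compound 3 of a 1.7-fold higher number from compound 1 to compound 3 (0.24 log units; within the scatter), towards a higher number but not clearly beyond the scatter. Compound 3 is therefore estimated at 40 nM, with a range of 12 nM to 150 nM.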

Compound 3, half-maximal inhibitory concentration: 35 nM
Estimate against measurement, compound 3: 1.1-fold (0.06 log units) above; measured number inside the range.
By their numbers in this assay, from the lowest: compounds 1 and 3 (each within the scatter of the next); then compound 2.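

In this assay, the place on the aromatic carbon next to the ring nitrogen takes a group of 6 heavy atoms, with a four-membered ring of carbon only and a five-membered non-aromatic ring with one hetero atom, in place of the oxolan-2-yl, and the result is a 1.5-fold higher number from compound 1 to compound 3 (0.18 log units; within the scatter). Within the data shown here, this is the first single-place comparison, and it shows that the oxolan-2-yl, with its ring oxygen and defined stereocentre, can be exchanged here for a group with nitrogen in its ring without a step beyond the scatter. The count of one hydrogen-bond acceptor and no donors is the same on both sides of this exchange. Nothing at hand bears on why these two groups give numbers within the scatter of each other.

From the compounds shown here alone, how far this place accepts other kinds of group remains open, for instance a dimethylamino, a morpholine or a carboxylic acid. Also open, going by these compounds, are the opposite configuration of the oxolan-2-yl and whether the same exchange gives a similar step on a different core.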